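Swapping Thiophene for Furan on a Bicyclic Lactam Core

The source may report more compounds than this note shows. Statements on the series, on what has been measured and on what is new or still open speak of the compounds shown alone.

Measured compounds:
compound 1 `COc1ccc(C2=C(c3cccs3)C(=O)N3CCCC3C2)cc1`: 5000 nM
compound 2 `COc1ccc(C2=C(c3ccsc3)C(=O)N3CCCC3C2)cc1`: 1500 nM

Of the compounds shown here, two sharing the same core have been tested in a functional assay on HCT-116 cells (Homo sapiens) for cytotoxicity (on this read-out lower numbers stand for stronger inhibition and higher numbers for weaker inhibition), so far. Compound 1 gives 5000 nM, and compound 2 gives 1500 nM. Among the compounds with values here, the single measured step, a 3.3-fold lower number from compound 1 to compound 2 (0.52 log units; beyond the scatter), shows that moving the attachment point of the thiophene ring matters. Compound 2 therefore stands as the lower of the two numbers, separated from compound 1 by a gap beyond the usual scatter.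

Compound 3 `COc1ccc(C2=C(c3ccoc3)C(=O)N3CCCC3C2)cc1` keeps the ring attached at the same position but changes the ring itself: furan-3-yl in place of thiophen-3-yl on a double-bonded ring carbon. Within the data shown here, no measured step covers a swap of sulfur for oxygen within this five-membered ring; the only step known, from compound 1 to compound 2, concerns the attachment point, not the identity of the hetero atom. Among the measured compounds shown here, with no direct precedent, the expected step of a 1.3-fold higher number from compound 2 to compound 3 (0.12 log units; within the scatter) in this assay is small, possibly not beyond the scatter, leaning toward a slightly higher number. Compound 3 is thus estimated at 2000 nM, with a range from 700 nM to 6000 nM.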

Compound 3, half-maximal inhibitory concentration: 3000 nM
Compound 3: middle estimate off by 1.5-fold (0.18 log units), on the low side; measured number inside the range.
By their numbers in this assay, from the lowest: compounds 2, 3 and 1 (each within the scatter of the next, the first and the last beyond it).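

In this assay, placing furan-3-yl in the spot held by thiophen-3-yl on this double-bonded ring carbon gives a change that cannot be told apart from repeat-measurement noise (a 2.0-fold higher number from compound 2 to compound 3 (0.30 log units; within the scatter)), so exchanging the ring sulfur for oxygen at this attachment point has no clear effect on the read-out. The furan ring is just as hard to separate from thiophen-2-yl (a 1.7-fold lower number from compound 1 to compound 3 (0.22 log units; within the scatter)), which means that among these three rings, only the two thiophene attachments stand apart beyond the scatter. Nothing available bears on why the numbers fall as they do.

From the compounds shown here alone, all three groups at this position are five-membered aromatic rings with one hetero atom, so it remains open whether furan-2-yl would repeat the gap seen between the two thiophene attachments, and how a phenyl ring, a pyridine or a small amine on the same carbon would read out. Going by these compounds, it is also open whether the sulfur-for-oxygen exchange would stay this quiet on other versions of the shared core.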